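Removing one chloro group from a dichlorophenyl amide

A few compounds are considered here, and "the series" means these few. Any claim that something is new, unique, unknown or untested is made for them only; others in the source may bear on it.

For the measured compounds named here, compound 1 `CC(Sc1nnc(-c2ccncc2)s1)C(=O)Nc1ccc(Cl)cc1Cl` and compound 2 `O=C(CSc1nnc(-c2ccncc2)s1)Nc1ccc(Cl)cc1Cl` are the two measured members of this set. In an ADME assay on BHK-21 cells (Mesocricetus auratus) for cytotoxicity, with a stated time of 3 days (a lower number here means that less compound is tolerated, a higher number that more compound is tolerated), compound 1 gave only a limit, > 50000 nM. For compound 2 this assay holds no single number, the entry reading "not determined" (no result reported). Going by the values given here, the one other value shown stands at the limit of > 50000 nM in this assay, at which 1 of the 2 values shown sits. Compound 3 `O=C(CSc1nnc(-c2ccncc2)s1)Nc1ccccc1Cl` differs from compound 2 by hydrogen in place of chloro on an aromatic carbon. Among the compounds with values here, no measured step is available, so no shift beyond the usual scatter in this assay is expected. Compound 3 is expected near 50000 nM, between 20000 nM and 100000 nM.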

Compound 3, half-maximal cytotoxic concentration: > 50000 nM
Compound 3 ended at the assay's limit; the forecaster's own chance of this, stated with the estimate: 70%; the middle value sits exactly at the limit.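

No step can be read between compound 2 and compound 3, and the result for compound 3 is only a limit: the limit of > 50000 nM in this assay, at which 2 of the 3 values shown sit.

The compounds shown leave open whether replacing this chloro group with hydrogen shifts the result in this assay at all.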